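Moving the pyridine nitrogen in a chalcone-type series

The source may report more compounds than this note shows. Statements on the series, on what has been measured and on what is new or still open speak of the compounds shown alone.

Compound 1, `O=C(/C=C/c1cn(-c2ccccc2)nc1-c1cccnc1)c1ccccc1`: in a functional assay on MCF7 cells (Homo sapiens) for inhibition, read by sulforhodamine B assay, with a stated time of 72 h (on this read-out lower numbers stand for stronger inhibition and higher numbers for weaker inhibition), compound 1 gives 4100 nM.
Compound 2, `COc1cc(C(=O)/C=C/c2cn(-c3ccccc3)nc2-c2cccnc2)cc(OC)c1OC`: in this assay compound 2 gives 14500 nM.
Compound 3, `O=C(/C=C/c1cn(-c2ccccc2)nc1-c1ccncc1)c1ccccc1`: in this assay compound 3 gives 3400 nM.

Compound 1 and compound 3 share one core and differ in a single place: pyridin-4-yl in place of pyridin-3-yl on an aromatic carbon. That change made the step of a 1.2-fold lower number from compound 1 to compound 3 (0.08 log units; within the scatter), so the two compounds cannot be ordered against each other. Compound 2 rests on a different core; the difference between the two cores is not broken down here. Compound 2 gives the highest number of the three, and its gaps to compound 1 and to compound 3 both lie beyond the scatter, so on this read-out compound 2 is the weakest inhibitor of the measured set.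

Compound 4, `COc1cc(C(=O)/C=C/c2cn(-c3ccccc3)nc2-c2ccncc2)cc(OC)c1OC`, has not yet been measured in this assay. It differs from compound 2 as follows: pyridin-4-yl in place of pyridin-3-yl on an aromatic carbon. Within the data shown here, this is the same change, at the same place, that turned compound 1 into compound 3, so the only guide is that one earlier step. Compound 4 is expected to give about 12000 nM in this assay, within an estimated range from 5000 nM to 30000 nM. The expected step is a 1.2-fold lower number from compound 2 to compound 4 (0.08 log units; within the scatter), kept small because a 1.2-fold lower number from compound 1 to compound 3 (0.08 log units; within the scatter) stayed within the scatter, with a wide range since it rests on a single precedent.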

Compound 4, half-maximal inhibitory concentration: 3500 nM
Compound 4: middle estimate off by 3.4-fold (0.54 log units), on the high side, outside the stated range (below it).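

In this assay, the same swap of pyridin-3-yl for pyridin-4-yl gives a 4.1-fold lower number from compound 2 to compound 4 (0.62 log units; beyond the scatter), so a change that could not be told from the scatter on the core of compound 1 does show on the core of compound 2, and the two steps disagree: the same change on two cores in this assay, a 1.2-fold lower number (0.08 log units; within the scatter) from compound 1 to compound 3 and a 4.1-fold lower number (0.62 log units; beyond the scatter) from compound 2 to compound 4, 3.4-fold (0.54 log units) apart, beyond the scatter of two such steps
In this small series, then, the size of this step does not carry over from one core to the other, and a result from one core is a poor guide to the other. This does not show which part of the core of compound 2 makes the difference or why, and each step rests on a single pair of compounds, so it sets no general rule for either core.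

Whether the methoxy groups alone account for the gap between the steps stays open, as does what an amine or a carboxylic acid in their place would do to the step. Also open, on these data alone, is how pyridin-2-yl would behave at the same place on the five-membered ring, on either core.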